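Methoxy Groups on Two Isoxazoline Cores

The compounds below may be only part of what the source reports. "The series", "measured", "known", "first", "only" and "open" are said of these compounds alone.

Measured compounds:
compound 1 `COc1cc(C2=NOC(c3c[nH]c4ccccc34)C2)cc(OC)c1OC`: 11700 nM
compound 2 `COc1ccc(C2=NOC(c3c[nH]c4ccccc34)C2)cc1OC`: a limit, > 100000 nM
compound 3 `c1ccc2c(C3CC(c4ccncc4)=NO3)c[nH]c2c1`: 19700 nM

In a functional assay on MDA-MB-231 cells (Homo sapiens) for inhibition, read by MTT assay, with a stated time of 48 h (on this read-out lower numbers stand for stronger inhibition and higher numbers for weaker inhibition), compound 1 gives 11700 nM. For compound 2 the read-out is a limit of the assay, not a number: > 100000 nM (the limit of > 100000 nM in this assay, at which 1 of the 3 values shown sits). The change methoxy in place of hydrogen on an aromatic carbon gave an at least 8.5-fold lower number from compound 2 to compound 1 (0.93 log units; beyond the scatter). Compound 3 gives 19700 nM; how its core differs from that of compound 2 is not broken down here. Compound 4 `COc1ccc2[nH]cc(C3CC(c4ccncc4)=NO3)c2c1` is not yet measured; it differs from compound 3 by methoxy in place of hydrogen on an aromatic carbon. This is the same kind of change as from compound 2 to compound 1, but the place differs: there the entering methoxy was ortho to a methoxy group, meta to a large group and meta to a methoxy group; here it sits on a ring that is part of a fused system of two rings, meta and para to a fused ring. Because the earlier step of an at least 8.5-fold lower number from compound 2 to compound 1 (0.93 log units; beyond the scatter) was at least modest, a smaller step of a 2.0-fold lower number from compound 3 to compound 4 (0.29 log units; within the scatter) is expected here. Compound 4 is estimated at 10000 nM, between 3000 nM and 40000 nM.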

Compound 4, half-maximal inhibitory concentration: > 100000 nM
Compound 4 was reported as a limit; the forecaster's own chance of this, stated with the estimate: 15%; middle value at least 10-fold (1.00 log units) away from the limit.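

The same change, methoxy in place of hydrogen on an aromatic carbon, did not carry over from one core to the other in this assay: the same change on two cores in this assay, an at least 8.5-fold lower number (0.93 log units; beyond the scatter) from compound 2 to compound 1 and an at least 5.0-fold higher number (0.70 log units; beyond the scatter) from compound 3 to compound 4, at least 43-fold (1.63 log units) apart, beyond the scatter of two such steps. On the core of compound 3 it gave an at least 5.0-fold higher number from compound 3 to compound 4 (0.70 log units; beyond the scatter), the opposite direction to the earlier step, but the methoxy also entered at a different kind of place, so these data do not show whether the core or the place decides the outcome. For compound 4 the read-out of > 100000 nM is a limit of the assay, not a number.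

Still open, going by these compounds, is how a different group, such as a hydroxyl, a fluorine or an amine, would behave at the same carbon of compound 3. Also open, on these data alone, is whether methoxy elsewhere on that fused ring system would give the same result.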